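Flipping One Ring Stereocentre: From Compound 1 to Compound 4

A few compounds are considered here, and "the series" means these few. Any claim that something is new, unique, unknown or untested is made for them only; others in the source may bear on it.

Of the compounds shown here, three sharing the same core have been measured in an assay on membranes from Chem-1 cells for displacement of a labelled ligand from prostaglandin E2 receptor EP3 subtype (Homo sapiens), read by scintillation counting, with a stated time of 2 h; on this read-out higher numbers stand for weaker inhibition and lower numbers for stronger inhibition. Compound 1 `CC(C)[C@H](C[C@H]1OC(=O)NC1=O)c1ccc(-c2ccc3cccc(F)c3c2)[nH]c1=O` gives 6 nM, the lowest of the three numbers and so the strongest inhibition seen. Compound 2 `CCC(/C=C1\OC(=O)NC1=O)(CC)c1ccc(-c2ccc3cccc(F)c3c2)[nH]c1=O` gives 13 nM, a step beyond the scatter away from compound 1, and compound 3 `CC(C)C(/C=C1\NC(=O)NC1=O)c1ccc(-c2ccc3cccc(F)c3c2)[nH]c1=O` gives 43 nM, further still. None of these pairs differ in only one place, so they show the spread of the set rather than a single change.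

Compound 4 `CC(C)[C@H](C[C@@H]1OC(=O)NC1=O)c1ccc(-c2ccc3cccc(F)c3c2)[nH]c1=O` has not yet been measured. Set against compound 1, (the two compounds have the same atoms and bonds and differ only in configuration as drawn: 1 of 2 stereo elements differ; a stereocentre at a saturated ring carbon is drawn R in compound 1 and S in compound 4). The other stereo element is kept.

Within the data shown here, no measured pair shows what such a flip does here. Changes of configuration alone often shift binding, and in either direction, so a step beyond the scatter toward weaker inhibition is expected, though a flat result cannot be ruled out. The step from compound 1 to compound 4 in this assay is expected to be a 5.0-fold higher number from compound 1 to compound 4 (0.70 log units; beyond the scatter). Compound 4 is therefore estimated at 30 nM, with a range of 6 nM to 150 nM.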

Compound 4, inhibition constant: 8 nM
The estimate for compound 4 lay 3.8-fold (0.57 log units) above the measured number, within the range that was stated.
By their numbers in this assay, from the lowest: compounds 1, 4 and 2 (each within the scatter of the next, the first and the last beyond it); then compound 3.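

In this assay, flipping the stereocentre at the saturated ring carbon from R to S gives a 1.3-fold higher number from compound 1 to compound 4 (0.12 log units; within the scatter), so the measurement does not tell the two drawn configurations at this carbon apart. Among these compounds, the earlier compounds could not show this, since no two of them differed in only one place, and this is the first pair to isolate a single change. The step can be read as the effect of configuration at that carbon alone: the fact that compounds 1 and 4 differ only in the configuration as drawn

On these data alone, the other stereo element is the same in compound 1 and compound 4, so what flipping it would do remains open. Also open is how this assay would read if a carboxylic acid replaced the ring that carries this stereocentre, since every compound shown keeps a ring at that place.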